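The source may hold more compounds than are shown below. What is called first, only, known or untested is meant among the compounds shown, and "the series" means these compounds.

Compound 2, `CCCS(=O)(=O)Nc1ccc(F)c(C(=O)c2n[nH]c3ncc(-c4ccc(S(N)(=O)=O)cc4F)cc23)c1F`, was measured in an assay for binding affinity to dual specificity mitogen-activated protein kinase kinase 4 (Homo sapiens), read by KINOMEscan, tested at 10 nM (on this read-out lower numbers stand for a stronger effect and higher numbers for a weaker effect at the one concentration tested), and gave 9.4%. Among the measured compounds shown here, that number is the higher of the two measured so far: the closest neighbour is compound 1, `CCCS(=O)(=O)Nc1ccc(F)c(C(=O)c2n[nH]c3ncc(-c4ccc(N)cc4)cc23)c1F`, with 3.7%, and the step of a number 5.7 percentage points higher from compound 1 to compound 2 (within the scatter) lies within the scatter, so on this read-out the two compounds are not distinguished. Compound 3, `CCCS(=O)(=O)Nc1ccc(F)c(C(=O)c2n[nH]c3ncc(-c4ccc(S(N)(=O)=O)cc4C)cc23)c1F`, has not yet been measured. It differs from compound 2 in one place: methyl in place of fluoro on an aromatic carbon. For the measured compounds named here, the single measured step, from compound 1 to compound 2, exchanged the whole aryl substituent and still moved the number by only a number 5.7 percentage points higher from compound 1 to compound 2 (within the scatter); the change from compound 2 to compound 3 is smaller in scope, touching one heavy atom at the same ring. Going by the values given here, no measured pair tests a methyl against a fluoro on this aryl group, so the expectation rests on the small size of the one step seen. In this assay compound 3 is therefore expected to give about 9%, between 3% and 20%, and the expected step of a number 0.4 percentage points lower from compound 2 to compound 3 (within the scatter) is not expected to exceed the scatter.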

Compound 3, a percentage reported as activity, at one concentration (the size of the read-out at that concentration, not a potency): 24%
Estimate against measurement, compound 3: 15 percentage points below; measured number above the stated range.
By their numbers in this assay, from the lowest: compounds 1 and 2 (each within the scatter of the next); then compound 3.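

In this assay the exchange of fluoro for methyl on this aromatic carbon, ortho to a large group and meta to a sulfamoyl group, gives a number 14.6 percentage points higher from compound 2 to compound 3 (beyond the scatter) and so lies beyond the scatter, although it replaces one heavy atom with one heavy atom. The earlier compounds shown here did not show this sensitivity: replacing the whole aryl substituent gave only a number 5.7 percentage points higher from compound 1 to compound 2 (within the scatter) and left the two compounds undistinguished, whereas the 2-methyl-4-sulfamoylphenyl group gives a number 20.3 percentage points higher from compound 1 to compound 3 (beyond the scatter) and places compound 3 as the weakest of the three at the one concentration tested. The data offer no measured basis for explaining why methyl and fluoro differ at this carbon.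

As far as these compounds go, it remains open whether this shift is particular to methyl or would also appear with a chlorine atom, a methoxy group or a plain hydrogen on the same carbon. From the compounds shown here alone, it is equally open whether the methyl-for-fluoro exchange would give a step of similar size if an amine or a carboxylic acid stood in place of the sulfamoyl group on this ring.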